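The source may hold more compounds than are shown below. What is called first, only, known or untested is meant among the compounds shown, and "the series" means these compounds.

Compound 1 `CCN(CC)CC(=O)Nc1ccc(Nc2nc3cc(OC)ccc3cc2-c2ccc(OC)cc2)cc1` carries a diethylamino group on the saturated chain carbon bound to the carbonyl carbon of the amide. In a functional assay on HUVEC cells (Homo sapiens) for antiproliferative activity, read by MTT assay, with a stated time of 48 h (on this read-out lower numbers stand for stronger inhibition and higher numbers for weaker inhibition), compound 1 gives 14000 nM. For the measured compounds named here, the only other measured member of the series is compound 2 `COc1ccc(-c2cc3ccc(OC)cc3nc2Nc2ccc(NC(=O)CN3CCCC3)cc2)cc1`, which in this assay gives 8600 nM; the two numbers lie within the scatter of each other, as a 1.6-fold lower number from compound 1 to compound 2 (0.21 log units; within the scatter) shows, so compound 1 cannot be set apart from compound 2 on these data.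

Compound 3 `COc1ccc(-c2cc3ccc(OC)cc3nc2Nc2ccc(NC(=O)CN3CCN(C)CC3)cc2)cc1` has not yet been measured. It differs from compound 1 by 4-methylpiperazin-1-yl in place of diethylamino on a saturated chain carbon bound to a carbonyl carbon. Going by the values given here, the one measured step that bears on this exchange is the replacement of the same diethylamino group by another cyclic amine, a 1.6-fold lower number from compound 1 to compound 2 (0.21 log units; within the scatter), which stayed within the scatter. On that basis no step beyond the scatter is expected from compound 1 to compound 3 in this assay; the expected step is a 1.5-fold lower number from compound 1 to compound 3 (0.17 log units; within the scatter), a small drift toward lower numbers at most. Compound 3 is therefore estimated at 9500 nM, with a range from 4000 nM to 22000 nM.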

Compound 3, half-maximal inhibitory concentration: 7400 nM
For compound 3 the middle estimate is 1.3-fold (0.11 log units) above the measured one; the measured number falls inside the stated range.
By their numbers in this assay, from the lowest: compounds 3, 2 and 1 (each within the scatter of the next).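

In this assay, the place on a saturated chain carbon bound to a carbonyl carbon now also holds 4-methylpiperazin-1-yl, a six-membered non-aromatic ring with 2 hetero atoms, and the exchange for diethylamino stays within the scatter (a 1.9-fold lower number from compound 1 to compound 3 (0.28 log units; within the scatter)). The two cyclic amines also cannot be told apart (a 1.2-fold lower number from compound 2 to compound 3 (0.07 log units; within the scatter)), so 4-methylpiperazin-1-yl and pyrrolidin-1-yl give no readable difference at this place. All three amine groups shown therefore fall within the scatter in this assay, and no measurement at hand speaks to why this exchange leaves the number so little moved.

On these data alone, whether a basic amine is needed here at all stays open, since a morpholin-4-yl group, a primary amine, a hydroxyl group or a carboxylic acid on the same chain carbon would test this more sharply than another tertiary amine. As far as these compounds go, a longer chain between the carbonyl and the amine is equally open, as is whether any change at this place can produce a step beyond the scatter.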